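Bromo in Place of Methoxy on a Propargylamine Thioether

A few compounds are considered here, and "the series" means these few. Any claim that something is new, unique, unknown or untested is made for them only; others in the source may bear on it.

Three compounds have been measured in an ADME assay on isolated protein for inhibition of Amine oxidase [flavin-containing] B (Homo sapiens); on this read-out lower numbers stand for stronger inhibition and higher numbers for weaker inhibition:

compound 1 `C#CCNC1CCc2c(SCc3ccc4ccccc4c3)cccc21` gives 69300 nM
compound 2 `C#CCNC1CCc2c(SCc3cccc(OC)c3)cccc21` gives 1520 nM
compound 3 `C#CCNC1CCc2c(NCc3cccc(C(F)(F)F)c3)cccc21` gives 11300 nM

Compound 2 stands with the lowest number of the three, which on this read-out means the strongest inhibition. Its nearest neighbour is compound 3, whose number is higher by a gap that lies beyond the scatter of repeated measurements, and compound 1 lies furthest away, also well beyond the scatter. The three compounds share a core and differ in the group on the sulfur or nitrogen linker and in the substituent on the outer ring, so none of them is separated from another by a single change, and no measured step can be read off.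

The next compound, compound 4 `C#CCNC1CCc2c(SCc3cccc(Br)c3)cccc21`, is compound 2 with one change: bromo in place of methoxy on an aromatic carbon

Both groups sit on an aromatic carbon of a six-membered aromatic ring of carbon only. For the measured compounds named here, nothing among the measured compounds tells what this swap does on its own. The expected step is small, within or only just beyond the scatter, and is estimated as a 1.4-fold lower number from compound 2 to compound 4 (0.14 log units; within the scatter), leaning slightly towards stronger inhibition. Compound 4 is therefore expected to give about 1100 nM in this assay, with a likely range from 250 nM to 5000 nM.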

Compound 4, half-maximal inhibitory concentration: > 100000 nM
Compound 4: only a limit was reported; the forecaster's own chance of this, stated with the estimate: 2%; middle value at least 90-fold (1.95 log units) away from the limit.
By their numbers in this assay, from the lowest: compound 2; then compound 3; then compound 1. At a limit, above all of these: compound 4.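

In this assay compound 4 gives > 100000 nM, which is a limit of the assay and not a number. Putting bromo in place of methoxy on this aromatic carbon, meta to a large group, gives an at least 65-fold higher number from compound 2 to compound 4 (1.81 log units; beyond the scatter). For the compounds shown here, this is the first step here between compounds that differ in one place, and it shows that replacing one small group with another at this position can take away most or all of the inhibition seen with compound 2, so the choice of group here matters a great deal. The full size of the step cannot be read, because compound 4 sits at a limit and has no exact number: the limit of > 100000 nM in this assay, at which 1 of the 4 values shown sits.

The compounds shown cannot tell whether the loss comes from bringing in bromo or from removing methoxy; a chloro, hydroxy or ethoxy group on the same carbon would help to separate the two. They also leave open whether the same swap would have a similar effect with the nitrogen linker of compound 3 in place of the sulfur linker.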